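A few compounds are considered here, and "the series" means these few. Any claim that something is new, unique, unknown or untested is made for them only; others in the source may bear on it.

Compounds measured so far:

compound 1, `Cc1ccc(C)c(-c2nc(CN3CCC(C(=O)NCCCN4C[C@H](C)C[C@H](C)C4)CC3)c(C)o2)c1`, 4070 nM
compound 2, `Cc1ccccc1-c1nc(CN2CCC(C(=O)NCCCN3CCC(C(C)C)CC3)CC2)c(C)o1`, 4280 nM
compound 3, `Cc1ccccc1-c1nc(CN2CCC(C(=O)NCCCN3CCCC(CC(C)C)C3)CC2)c(C)o1`, 4640 nM

All three numbers come from an ADME assay on Huh7.5.1 cells (Homo sapiens) for cytotoxicity, read by ATP content, with a stated time of 48 h; a lower number here means that less compound is tolerated, a higher number that more compound is tolerated. Compound 1 stands with the other two: its distance to compound 2 and to compound 3 is within the usual scatter of repeated measurements, so no order among the three can be claimed.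

Compound 4, `Cc1cccc(-c2nc(CN3CCC(C(=O)NCCCN4C[C@H](C)C[C@H](C)C4)CC3)c(C)o2)c1`, has not yet been measured in this assay. It is derived from compound 1 by the change (hydrogen in place of methyl on an aromatic carbon), that is, 2,5-dimethylphenyl becomes 3-methylphenyl, while the rest of the shared core is unchanged.

Within the data shown here, the one measured step, a 1.1-fold higher number from compound 2 to compound 3 (0.04 log units; within the scatter), concerns the group on a saturated chain carbon three bonds from the amide-type nitrogen, not the aromatic ring, and is itself within the scatter. Nothing measured here bears directly on removal of a methyl from that aromatic ring, and the three measured compounds, with differing aryl groups, sit within the scatter of one another.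

Compound 4 is therefore expected to show a step of a 1.1-fold higher number from compound 1 to compound 4 (0.03 log units; within the scatter), that is, no change beyond the scatter. The estimate for compound 4 in this assay is 4400 nM, with a range from 2000 nM to 9500 nM.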

Compound 4, half-maximal cytotoxic concentration: 16500 nM
Compound 4: the middle estimate sits 3.8-fold (0.57 log units) below what was measured, outside the stated range (above it).
By their numbers in this assay, from the lowest: compounds 1, 2 and 3 (each within the scatter of the next); then compound 4.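

In this assay, replacing the methyl with hydrogen, on the aromatic carbon ortho to a large group and para to a methyl group, gives a 4.1-fold higher number from compound 1 to compound 4 (0.61 log units; beyond the scatter). Among these compounds, this shows that the 2,5-dimethylphenyl to 3-methylphenyl change, a loss of a single carbon, is enough to move the number beyond the scatter, whereas the only earlier step, a 1.1-fold higher number from compound 2 to compound 3 (0.04 log units; within the scatter), concerned a group on a saturated chain carbon and did not. The data shown offer no measured account of why this change has such an effect.

As far as these compounds go, whether a chlorine or a methoxy group on this aromatic carbon would give a number nearer that of compound 1 or that of compound 4 remains open. Also open, from the compounds shown here alone, is whether the same step would appear with a different amine at the end of the chain.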